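This account rests on a few compounds, and the source may have more. Where it says the series, first, only, none or still open, it means among the compounds named here.

Within the data shown here, compound 3, `c1ccc(-c2ccoc2)c(OCC2=NCCN2)c1`, is the anchor of this small set: in a functional assay for activation of Alpha-1D adrenergic receptor (Homo sapiens), read by calcium flux (a higher number here means that more compound is needed for the effect, a lower number that less compound is needed), compound 3 gives 5.01 nM, and it is the only number among the three measured compounds. Compound 1, `c1ccc(-c2ccncn2)c(OCC2=NCCN2)c1`, in this assay gives < 100000 nM, which is a limit of the assay and not a number. Compound 2, `c1coc(-c2ccccc2OCC2=NCCN2)c1`, in this assay gives < 100000 nM, again a limit. Accordingly the steps a step that the limit leaves unreadable from compound 1 to compound 3, a step that the limit leaves unreadable from compound 2 to compound 3 and a step that the two limits leave unreadable from compound 1 to compound 2 cannot be sized, because of the limit of < 100000 nM in this assay, at which 2 of the 3 values shown sit. Compound 4, `c1ccc(-c2nccs2)c(OCC2=NCCN2)c1`, carries the change (1,3-thiazol-2-yl in place of furan-3-yl on an aromatic carbon). Among the measured compounds shown here, no measured step bears on this change with a readable size, so the expectation rests on compound 3 alone and is broad; a step of a 6.0-fold higher number from compound 3 to compound 4 (0.78 log units; beyond the scatter) toward weaker activation is estimated, since the two limits leave open how far a different five-membered ring may move the value. Compound 4 is therefore estimated to give 30 nM in this assay, with a range from 3 nM to 600 nM.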

Compound 4, half-maximal effective concentration: 31.6 nM
The estimate for compound 4 lay 1.1-fold (0.02 log units) below the measured number; the measured number falls inside the stated range.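

In this assay, the change from furan-3-yl to 1,3-thiazol-2-yl gives a 6.3-fold higher number from compound 3 to compound 4 (0.80 log units; beyond the scatter), the first readable size at this position, on an aromatic carbon ortho to a group of 7 heavy atoms. Compound 3 therefore no longer stands alone, as a second five-membered aromatic ring at this place, here with 2 hetero atoms, also gives a number rather than a limit. The steps to compound 4 from compound 1 and from compound 2 still cannot be read, as each rests on a limit of the assay and not a number: the limit of < 100000 nM in this assay, at which 2 of the 4 values shown sit.

The compounds shown do not separate the contribution of the ring nitrogen from that of the sulfur, or either from that of the point of attachment. Going by these compounds, how a thiophen-3-yl, a plain phenyl or an amine would read at this place remains open.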